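From Carbamoyl to (Ethylsulfanyl)carbonyl on the Shared Core

A few compounds are considered here, and "the series" means these few. Any claim that something is new, unique, unknown or untested is made for them only; others in the source may bear on it.

Measured so far:
Compound 1, `CC1=C(C(N)=O)C(c2ccoc2)NC(=O)N1`: 2%
Compound 2, `CC1=C(C(N)=O)C(c2ccsc2)NC(=O)N1`: 1%

Both compounds were tested in an assay on membranes from HeLa cells for displacement of a labelled ligand from adenosine receptor A3 (Homo sapiens), read by scintillation counting, with a stated time of 180 min, tested at 1 uM (on this read-out lower numbers stand for less inhibition and higher numbers for more inhibition at the one concentration tested (going by the name of the read-out)), at a single concentration. Compound 1 gives 2% and compound 2 gives 1%, so in this assay neither displaces much of the labelled ligand. Among the measured compounds shown here, the only measured step, a number 1 percentage points lower from compound 1 to compound 2 (within the scatter), comes from putting thiophen-3-yl in place of furan-3-yl on a saturated ring carbon, and it lies within the scatter. Compound 2 thus has the lowest of the two numbers, with compound 1 nearest to it, a gap that is within the scatter.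

Compound 3, `CCSC(=O)C1=C(C)NC(=O)NC1c1ccsc1`, is not yet measured. It differs from compound 2 by ethylsulfanyl in place of amino on a carbonyl carbon. For the measured compounds named here, no measured step touches this part of the molecule: the one step recorded concerns the ring on the saturated carbon, not the carbonyl carbon. The expectation therefore rests only on the two low readings, and compound 3 is expected to show a number 4 percentage points higher from compound 2 to compound 3 (within the scatter) in this assay. Compound 3 is estimated at 5%, within a range from -8% to 25%.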

Compound 3, a percentage reported as inhibition, at one concentration (the size of the read-out at that concentration, not a potency): 2%
Compound 3: middle estimate off by 3 percentage points, on the high side, and the stated range covers the measured number.
By their numbers in this assay, from the lowest: compounds 2, 1 and 3 (each within the scatter of the next).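

In this assay, among the compounds shown here, ethylsulfanyl in place of amino on a carbonyl carbon gives a number 1 percentage points higher from compound 2 to compound 3 (within the scatter), and this is the first measured step at this position rather than at the ring on the saturated carbon. Going from carbamoyl to (ethylsulfanyl)carbonyl swaps one group for a larger one with a different hydrogen-bond count, yet the number stays within the scatter, so this change alone gives no measurable displacement of the labelled ligand at the one concentration tested. Nothing at hand accounts for this result.

On these data alone, what stays open is whether any other group on this carbonyl carbon can lift the number clear of the scatter, for instance a carboxylic acid, an ethoxy group with oxygen in place of the sulfur, or a longer chain such as hexylsulfanyl. Also open, as far as these compounds go, is whether (ethylsulfanyl)carbonyl would read the same with furan-3-yl on the saturated ring carbon, and whether a different ring there, such as phenyl, would change the picture.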